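Methoxy for Chloro on the Aryl Ring of Compound 2

The source may report more compounds than this note shows. Statements on the series, on what has been measured and on what is new or still open speak of the compounds shown alone.

Measured compounds:
Compound 1 `O=C1CSC(c2c(Cl)cccc2Cl)N1CCN1CCCCC1`: 100%
Compound 2 `O=C1CSC(c2cccc(Cl)c2)N1CCN1CCCCC1`: 100%
Compound 3 `Cc1ccc(C2SCC(=O)N2CCN2CCCCC2)cc1`: 100%

In an ADME assay on Vero cells (Chlorocebus sabaeus) for cytotoxicity, read by neutral red uptake, tested at 12.3 ug/mL (a higher number here means a weaker effect of the compound at the concentration tested, a lower number a stronger effect), compound 2 gives 100%, and it sits level with compound 1 and compound 3, both of which show no change from it within the scatter. Going by the values given here, the one step already measured on the aryl ring, no change at the digits printed from compound 2 to compound 3 (within the scatter), left the read-out where it was.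

Compound 4 `COc1cccc(C2SCC(=O)N2CCN2CCCCC2)c1` has not yet been measured. It differs from compound 2 in one place: methoxy in place of chloro on an aromatic carbon. Among the compounds with values here, the only comparable step, from compound 2 to compound 3, moved nothing beyond the scatter, so compound 4 is expected to behave alike, with a step of no change at the digits printed from compound 2 to compound 4 (within the scatter). Compound 4 is therefore estimated at 100%, between 90% and 100%.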

Compound 4, a percentage reported as activity, at one concentration (the size of the read-out at that concentration, not a potency): 100%
Compound 4: middle estimate and measured number agree at the digits printed, within the range that was stated.
By their numbers in this assay, from the lowest: compounds 1, 2, 3 and 4 (each within the scatter of the next).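

In this assay, methoxy in place of chloro gives a step of no change at the digits printed from compound 2 to compound 4 (within the scatter) and, unlike the earlier step to compound 3, this change stays on an aromatic carbon meta to a large group. At this place, then, the read-out holds when the group gains a hydrogen-bond acceptor that chloro lacks. No evidence is available that bears on this result. Going by these compounds, whether an amine or a carboxylic acid at this place would leave the read-out level remains open, as does the effect of a longer chain.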